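Methyl on the sulfonyl phenyl: two matched pairs

The compounds below may be only part of what the source reports. "The series", "measured", "known", "first", "only" and "open" are said of these compounds alone.

Compound 1 `O=C1/C(=C/c2ccncc2)CN(S(=O)(=O)c2ccccc2)C/C1=C\c1ccccc1F` gives 8400 nM in a functional assay on QGY-7703 cells (Homo sapiens) for cytotoxicity, read by MTT assay, with a stated time of 24 h; on this read-out higher numbers stand for weaker inhibition and lower numbers for stronger inhibition. Compound 2 `Cc1ccc(S(=O)(=O)N2C/C(=C\c3ccncc3)C(=O)/C(=C/c3ccccc3F)C2)cc1` carries methyl in place of hydrogen on an aromatic carbon. In this assay compound 2 reports > 20000 nM, which is a limit of the assay and not a number (the limit of > 20000 nM in this assay, at which 1 of the 3 values shown sits). The step is an at least 2.3-fold higher number from compound 1 to compound 2 (0.37 log units; beyond the scatter).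

Compound 3 `O=C1/C(=C/c2cccnc2)CN(S(=O)(=O)c2ccccc2)C/C1=C\c1ccccc1C(F)(F)F` gives 6240 nM in this assay; the difference between the cores of compound 1 and compound 3 is not broken down here. Compound 4 `Cc1ccc(S(=O)(=O)N2C/C(=C\c3cccnc3)C(=O)/C(=C/c3ccccc3C(F)(F)F)C2)cc1` differs from compound 3 by methyl in place of hydrogen on an aromatic carbon, the same change as between compound 1 and compound 2, at the same place.

For compound 4 a step of a 2.4-fold higher number from compound 3 to compound 4 (0.38 log units; beyond the scatter) is expected, resting on the earlier at least 2.3-fold higher number from compound 1 to compound 2 (0.37 log units; beyond the scatter). That expected step starts from compound 3 with its value of 6240 nM. Compound 4 is therefore estimated at 15000 nM, within 6000 nM to 40000 nM.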

Compound 4, half-maximal inhibitory concentration: 6170 nM
Beside the measured number, compound 4's estimate is 2.4-fold (0.39 log units) above it, within the range that was stated.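

In this assay, methyl in place of hydrogen on the core of compound 3 gives a 1.0-fold lower number from compound 3 to compound 4 (0.00 log units; within the scatter), so on this core the change leaves no readable effect. The two pairs read together as follows: the same change on two cores in this assay, an at least 2.3-fold higher number (0.37 log units; beyond the scatter) from compound 1 to compound 2 and a 1.0-fold lower number (0.00 log units; within the scatter) from compound 3 to compound 4; the limit leaves it open whether they differ. They therefore show neither that the change carries from one core to the other nor that it fails to, and two pairs support no rule for the series.

The cores of compound 1 and compound 3 differ in more than one place, and the compounds shown do not assign any difference between the pairs to either place. Also open, from the compounds shown here alone, is how an amine, a carboxylic acid or a longer chain in place of the methyl would read on either core.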